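Methoxy on the shared core: cytotoxicity notes

The source may hold more compounds than are shown below. What is called first, only, known or untested is meant among the compounds shown, and "the series" means these compounds.

Three analogues on one core are measured in a functional assay on MCF7 cells (Homo sapiens) for cytotoxicity, read by MTT assay, with a stated time of 72 h; on this read-out lower numbers stand for higher toxicity in this test and higher numbers for lower toxicity in this test. Compound 1 `COc1ccc(CNc2nc([SeH])nc3ccccc23)cc1` reaches only the limit of the assay, > 100000 nM. Compound 2 `[SeH]c1nc(NCc2ccccc2)c2ccccc2n1` likewise returns a limit, > 100000 nM. Compound 3 `CSc1nc(NCc2ccccc2)c2ccccc2n1` also stops at a limit, > 100000 nM. The change from compound 2 to compound 1 is methoxy in place of hydrogen on an aromatic carbon, and its step, a step that the two limits leave unreadable from compound 2 to compound 1, cannot be sized. Going by the values given here, the cores of compound 2 and compound 3 differ by a group of 2 heavy atoms (1 carbon, 1 sulfur; no ring) in place of one selenium atom, on an aromatic carbon; the step that the two limits leave unreadable from compound 2 to compound 3 is equally unreadable, since the limit of > 100000 nM in this assay, at which 3 of the 3 values shown sit, holds for every value so far.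

Compound 4 `COc1ccc(CNc2nc(SC)nc3ccccc23)cc1` is not yet measured. It differs from compound 3 by methoxy in place of hydrogen on an aromatic carbon, the same change already made from compound 2 to compound 1, on the same place. Beside that earlier step, the step from compound 3 to compound 4 is expected to be a step that the limit leaves unreadable from compound 3 to compound 4, which rests on compound 1 having given > 100000 nM and on (the limit of > 100000 nM in this assay, at which 3 of the 3 values shown sit). For compound 4 a value of about 150000 nM is estimated, most likely between 50000 nM and 500000 nM.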

Compound 4, concentration lethal to 50% of the cells: > 100000 nM
Compound 4: a limit, no number; the forecaster's own chance of this, stated with the estimate: 85%; the middle value lies beyond the limit too.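

In this assay compound 4 gives > 100000 nM, a limit and not a number. The steps from compound 3 and from compound 1 to compound 4 therefore cannot be read: the limit of > 100000 nM in this assay, at which 4 of the 4 values shown sit.

The compounds shown leave open whether methoxy, or the two-atom group in place of selenium, changes toxicity in this assay on the shared core.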